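Replacing trifluoromethyl with phenyl on the pyrimidine core

The source may report more compounds than this note shows. Statements on the series, on what has been measured and on what is new or still open speak of the compounds shown alone.

Measured so far:
compound 1 `O=C(Nc1cc(C(F)(F)F)cc(C(F)(F)F)c1)c1cnc(Cl)nc1` — 300 nM
compound 2 `O=C(Nc1cc(C(F)(F)F)cc(C(F)(F)F)c1)c1cnc(Cl)nc1C(F)(F)F` — 50 nM

In an assay on Jurkat cells for activation of nuclear factor NF-kappa-B complex (Homo sapiens) (a higher number here means a weaker inhibitor, a lower number a stronger inhibitor), compound 2 gives the lowest of the two numbers so far, and the one step shown, a 6.0-fold lower number from compound 1 to compound 2 (0.78 log units; beyond the scatter), came from placing trifluoromethyl where hydrogen had stood. For the measured compounds named here, compound 3 `O=C(Nc1cc(C(F)(F)F)cc(C(F)(F)F)c1)c1cnc(Cl)nc1-c1ccccc1` keeps that position occupied but differs from compound 2 by phenyl in place of trifluoromethyl on an aromatic carbon, so the single measured step only shows that a group there can help; no step tells what a larger aromatic group does. For compound 3 the step of a 1.6-fold higher number from compound 2 to compound 3 (0.20 log units; within the scatter) is expected to stay small, with an estimated value of 80 nM in a range from 20 nM to 400 nM.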

Compound 3, half-maximal inhibitory concentration: 400 nM
The estimate for compound 3 lay 5.0-fold (0.70 log units) below the measured number; the range from low to high includes it.
By their numbers in this assay, from the lowest: compound 2; then compounds 1 and 3 (each within the scatter of the next).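

In this assay phenyl gives an 8.0-fold higher number from compound 2 to compound 3 (0.90 log units; beyond the scatter) and also a 1.3-fold higher number from compound 1 to compound 3 (0.12 log units; within the scatter) so filling this position does not by itself lower the number. Phenyl and hydrogen cannot be told apart here, and of the three groups only trifluoromethyl stands out. Nothing available explains the difference between these groups. On these data alone, whether methyl, an amine or a methoxy group at this position would give a number closer to that of compound 2 or to that of compound 1 remains open. Also open, as far as these compounds go, is whether a phenyl carrying a fluorine would behave like the plain phenyl of compound 3.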